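The source may report more compounds than this note shows. Statements on the series, on what has been measured and on what is new or still open speak of the compounds shown alone.

Compound 1 `O=C(Nc1ccc(Cl)cc1)C(=O)N1CCC(c2ccnc3ccc(F)cc23)CC1` gives 6900 nM in an assay on HEK cells for inhibition of Tryptophan 2,3-dioxygenase (Homo sapiens); on this read-out higher numbers stand for weaker inhibition and lower numbers for stronger inhibition. Putting a hydroxy in place of hydrogen on a saturated ring carbon gives compound 2 `O=C(Nc1ccc(Cl)cc1)C(=O)N1CC[C@@H](c2ccnc3ccc(F)cc23)[C@H](O)C1`, which shows 15300 nM, and compound 3 `O=C(Nc1ccc(Cl)cc1)C(=O)N1CC[C@H](c2ccnc3ccc(F)cc23)[C@H](O)C1`, which shows 17200 nM; the steps are a 2.2-fold higher number from compound 1 to compound 2 (0.35 log units; beyond the scatter) and a 2.5-fold higher number from compound 1 to compound 3 (0.40 log units; beyond the scatter). Between the two hydroxy compounds there is a 1.1-fold higher number from compound 2 to compound 3 (0.05 log units; within the scatter). Compound 3 thus carries the highest number of the three, close to compound 2 and furthest from compound 1. Compound 4 `O=C(Nc1ccc(Cl)cc1)C(=O)N1CC[C@@H](c2ccnc3ccc(F)cc23)[C@@H](O)C1` differs from compound 3 in that (the two compounds have the same atoms and bonds and differ only in configuration as drawn: 2 of 2 stereo elements differ (all stereocentres are inverted: mirror images); a stereocentre at a saturated ring carbon is drawn R in compound 3 and S in compound 4; a stereocentre at a saturated ring carbon is drawn S in compound 3 and R in compound 4). Among the compounds with values here, the only measured step that bears on a change of configuration alone is a 1.1-fold higher number from compound 2 to compound 3 (0.05 log units; within the scatter), a clean test because of the fact that compounds 2 and 3 differ only in the configuration as drawn. No step beyond the scatter is therefore expected in this assay. Compound 4 is expected to give about 15000 nM, within 6000 nM to 38000 nM. That estimate means a step of a 1.1-fold lower number from compound 3 to compound 4 (0.06 log units; within the scatter).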

Compound 4, half-maximal inhibitory concentration: 37000 nM
Beside the measured number, compound 4's estimate is 2.5-fold (0.39 log units) below it; the measured number falls inside the stated range.
By their numbers in this assay, from the lowest: compound 1; then compounds 2 and 3 (each within the scatter of the next); then compound 4.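

The drawn configuration of the hydroxy compounds alone can shift the number in this assay, with a 2.4-fold higher number from compound 2 to compound 4 (0.38 log units; beyond the scatter) and a 2.2-fold higher number from compound 3 to compound 4 (0.33 log units; beyond the scatter), whereas the earlier change of configuration stayed within the scatter. Hydroxy in place of hydrogen raises the number in all three compounds, and the size of that rise depends on configuration, reaching a 5.4-fold higher number from compound 1 to compound 4 (0.73 log units; beyond the scatter). The step to compound 4 from compound 2 is a direct test of a single stereocentre: the fact that compounds 2 and 4 differ only in the configuration as drawn

The compounds shown leave open whether an amine or a methoxy group on this ring carbon would behave like the hydroxy, and whether its configuration would matter as much.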